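The source may report more compounds than this note shows. Statements on the series, on what has been measured and on what is new or still open speak of the compounds shown alone.

Compound 1 `CCCCc1c(OC)nc2nc(C(=O)c3ccccc3)cn2c1CC` gives 10 mg/kg in a functional assay on the whole organism with Rattus norvegicus as the target; a lower number here means that less compound is needed, a higher number that more compound is needed for the effect. Compound 2 `CCCCc1c(OC)nc2nc(C(=O)c3ccccc3)cn2c1C` gives 2 mg/kg in this assay, the lowest of the three numbers, beyond the scatter from both others. Compound 3 `CCCc1c(SC)nc2nc(C(=O)c3ccccc3)cn2c1CC` gives 10 mg/kg in this assay; it differs from compound 1 in two places and its value matches that of compound 1. Compound 4 `COc1cc(C)n2cc(C(=O)c3ccccc3)nc2n1` differs from compound 2 by hydrogen in place of butyl on an aromatic carbon. For the measured compounds named here, the only single-point step, a 5.0-fold lower number from compound 1 to compound 2 (0.70 log units; beyond the scatter), bears loosely on this: shortening the saturated chain helped, but removing the whole butyl is a larger change with no direct precedent. For compound 4 a small rise is expected, a 2.0-fold higher number from compound 2 to compound 4 (0.30 log units; within the scatter), within the scatter. Compound 4 is estimated at 4 mg/kg, range 1 mg/kg to 20 mg/kg.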

Compound 4, minimum effective dose: 5 mg/kg
Compound 4: middle estimate off by 1.3-fold (0.10 log units), on the low side, within the range that was stated.
By their numbers in this assay, from the lowest: compound 2; then compounds 4, 1 and 3 (each within the scatter of the next).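

The step of a 2.5-fold higher number from compound 2 to compound 4 (0.40 log units; beyond the scatter) shows that this aromatic carbon tolerates losing its chain entirely: compound 4 still acts in the whole animal, though butyl gives the lower number. Every earlier compound carried a saturated chain here, so the series had not yet shown a hydrogen at this position. Nothing at hand explains the size of this step.

Open, from the compounds shown here alone, is how a propyl, a longer chain or an amine at this position would compare with butyl and hydrogen. Also open, going by these compounds, is whether the step holds when the methoxy group or the methyl group changes.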